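Two chlorines for one fluorine on compound 1

A few compounds are considered here, and "the series" means these few. Any claim that something is new, unique, unknown or untested is made for them only; others in the source may bear on it.

Three compounds share a common core and were tested in a functional assay on BGC-823 cells (Homo sapiens) for antiproliferative activity, read by MTT assay, tested at 1 uM; a higher number here means a stronger effect of the compound at the concentration tested, a lower number a weaker effect. Compound 1 `COc1cc(C2=NN(C(C)=O)C(c3cccc(F)c3)O2)cc(OC)c1OC` gives 14.7%. Compound 2 `COc1cc(C(=O)N/N=C/c2ccccc2C(F)(F)F)cc(OC)c1OC` gives 22.1%, a number within the usual scatter of compound 1. Compound 3 `COc1cc(C(=O)N/N=C/c2ccc(Cl)c([N+](=O)[O-])c2)cc(OC)c1OC` gives -5.8%, clearly lower than compound 1 and beyond the scatter. So compound 1 sits in the middle of the three, close to compound 2 and well above compound 3.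

Compound 4 `COc1cc(C2=NN(C(C)=O)C(c3c(Cl)cccc3Cl)O2)cc(OC)c1OC` is not yet measured. It differs from compound 1 in one place: 2,6-dichlorophenyl in place of 3-fluorophenyl on a saturated ring carbon. Going by the values given here, no measured pair shows this change, so the step is expected to be small and stay within the scatter. For compound 4 an inhibition of 18% is estimated, in a range from 5% to 34%. That estimate means a step of a number 3.3 percentage points higher from compound 1 to compound 4 (within the scatter), expected to be no larger than the scatter.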

Compound 4, a percentage reported as inhibition, at one concentration (the size of the read-out at that concentration, not a potency): -1.4%
Compound 4: middle estimate off by 19.4 percentage points, on the high side; the measured number lies below the stated range.
By their numbers in this assay, from the lowest: compounds 3 and 4 (each within the scatter of the next); then compounds 1 and 2 (each within the scatter of the next).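

On the saturated ring carbon of the shared core, the choice of aryl group makes a measurable difference: in this assay, 2,6-dichlorophenyl in place of 3-fluorophenyl gives a number 16.1 percentage points lower from compound 1 to compound 4 (beyond the scatter). Going by these compounds alone, this is the first comparison here in which only one place changes, so the drop can be traced to this swap. Nothing shown explains why the number falls.

The compounds shown leave open what a single chlorine on this phenyl ring would do. An amine or a carboxylic acid on the ring also remains to be compared with compound 1.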